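The source may hold more compounds than are shown below. What is called first, only, known or untested is meant among the compounds shown, and "the series" means these compounds.

In an in vitro ADME assay on microsomes from liver (Homo sapiens) for metabolic stability, using NADPH (on this read-out lower numbers stand for slow clearance and higher numbers for fast clearance), compound 1 (`COc1ccc(OC(F)(F)F)cc1Cn1c(C(=O)NCC(C)(C)CO)cc2cc(C#N)ccc21`) gives 69 mL.min-1.g-1. Two close relatives sit on the same scale: compound 2 (`COc1ccc(Cl)cc1Cn1c(C(=O)NCC(C)(C)CO)cc2cc(C#N)ccc21`) gives 83 mL.min-1.g-1 and compound 3 (`COc1ccc(Br)cc1Cn1c(C(=O)NCC(C)(C)CO)cc2cc(C#N)ccc21`) gives 104 mL.min-1.g-1 on this read-out. Compound 1 therefore stands level with both, as the steps show: a 1.2-fold higher number from compound 1 to compound 2 (0.08 log units; within the scatter) and a 1.5-fold higher number from compound 1 to compound 3 (0.18 log units; within the scatter), while the remaining pair shows a 1.3-fold higher number from compound 2 to compound 3 (0.10 log units; within the scatter). All three steps swap one group on an aromatic carbon and stay within the scatter.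

Compound 4 (`COc1ccc(OC(F)(F)F)cc1Cn1c(C(=O)NCC2(CO)CC2)cc2cc(C#N)ccc21`) keeps the core of compound 1 and differs elsewhere: 1-(hydroxymethyl)cyclopropyl in place of 1-(hydroxymethyl)-1-methylethyl on a saturated chain carbon bound to an amide-type nitrogen. Among the measured compounds shown here, the new group carries a three-membered ring, and no measured compound shows a change at this place. The three measured steps therefore bear on it only indirectly, and they offer no reason to expect a shift in this assay beyond the scatter. The expected step is a 1.2-fold lower number from compound 1 to compound 4 (0.06 log units; within the scatter), with no real difference anticipated. For compound 4 the estimated value is 60 mL.min-1.g-1, with an expected range from 33 mL.min-1.g-1 to 105 mL.min-1.g-1.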

Compound 4, intrinsic clearance in microsomes: 139 mL.min-1.g-1
Compound 4: middle estimate off by 2.3-fold (0.36 log units), on the low side; the whole stated range lies below it.
By their numbers in this assay, from the lowest: compounds 1, 2, 3 and 4 (each within the scatter of the next).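

Among the compounds shown here, this is the first look at the place on a saturated chain carbon bound to an amide-type nitrogen: in this assay, 1-(hydroxymethyl)cyclopropyl in place of 1-(hydroxymethyl)-1-methylethyl gives a 2.0-fold higher number from compound 1 to compound 4 (0.30 log units; within the scatter). So closing the three-membered ring, with the heavy-atom, donor and acceptor counts unchanged, leaves compound 4 level with compound 1 on this read-out, and a single pair cannot show a real difference at this place. No measurement shown gives a cause for this result.

On these data alone, it remains open whether the same swap would read alike on compound 2 or compound 3, which carry chloro and bromo on the shared core. Also open, as far as these compounds go, is how this place would respond to a different group, such as a four-membered carbon ring, a longer chain, an amine or a carboxylic acid.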